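The source may report more compounds than this note shows. Statements on the series, on what has been measured and on what is new or still open speak of the compounds shown alone.

In a functional assay on PC-3 cells (Homo sapiens) for antiproliferative activity, read by WST assay, with a stated time of 72 h (a lower number here means that less compound is needed, a higher number that more compound is needed for the effect), compound 3 `CCCCCCCC/C=C/c1c(C)c(/C=C/CCCCCCCC)c2[n+](c1C)CCC2` gives 0.6 uM. This is level with compound 1 `CCCCCCCCCCc1c(C)c(CCCCCCCCCC)c2[n+](c1C)CCC2`, which also gives 0.6 uM, while compound 2 `CCCCCCCC/C=C\c1c(C)c(/C=C\CCCCCCCC)c2[n+](c1C)CCC2` gives 1.1 uM, within the scatter of both. Among the compounds with values here, the three compounds therefore form a tight group on the numbers so far.

The next compound to be tested is compound 4 `CCCCCCCC/C=C\c1c(C)c(/C=C/CCCCCCCC)c(C)[n+]2c1CCC2`. Its relation to compound 3 is the two compounds have the same atoms and bonds and differ only in configuration as drawn: 1 of 2 stereo elements differ; a double bond is drawn E in compound 3 and Z in compound 4. No group leaves or enters, so the question is only what the geometry of that double bond does to the read-out.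

Within the data shown here, one measured step bears directly on this: a 1.8-fold lower number from compound 2 to compound 3 (0.26 log units; within the scatter). It lies within the scatter, and its interpretation rests on (the fact that compounds 2 and 3 differ only in the configuration as drawn). That step changed the drawn configuration of both double bonds, whereas the new step changes it at only one. A configurational change at both places did not move this assay beyond the scatter, so a change at one place is not expected to do so either. The expected change is a 1.3-fold higher number from compound 3 to compound 4 (0.12 log units; within the scatter), which would remain within the scatter. For compound 4 the estimated value is 0.8 uM, with an expected range from 0.4 uM to 1.6 uM.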

Compound 4, concentration for half-maximal effect: 0.7 uM
Beside the measured number, compound 4's estimate is 1.1-fold (0.06 log units) above it; measured number inside the range.
By their numbers in this assay, from the lowest: compounds 1, 3, 4 and 2 (each within the scatter of the next).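

In this assay, the earlier compounds had shown only a change of configuration at both double bonds together, whereas compound 4 allows one double bond to be read on its own from either side. One side gives a 1.2-fold higher number from compound 3 to compound 4 (0.07 log units; within the scatter), and the other gives a 1.6-fold lower number from compound 2 to compound 4 (0.20 log units; within the scatter), so both single changes stay within the scatter, as the change at both double bonds had done. On these numbers, the drawn geometry of a single double bond has no readable effect on the antiproliferative read-out, and the comparison isolates geometry alone, with no group leaving or entering: the fact that compounds 3 and 4 differ only in the configuration as drawn

All four compounds remain within a narrow band, so the data give no indication of which structural feature, if any, would separate them in this assay. Whether a shorter chain, or an amine or a carboxylic acid in place of one of these long chains, would move the number beyond the scatter remains open, as does any reason why the geometry leaves it unmoved.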